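A charged ring on the acetamide of compound 1

The source may hold more compounds than are shown below. What is called first, only, known or untested is meant among the compounds shown, and "the series" means these compounds.

For the measured compounds named here, compound 1, `CC(=O)Nc1ccc(C2=NNC(=O)CC2)cc1`, is the one compound here that returns a number. In a functional assay for inhibition, with Homo sapiens as the target (a higher number here means that more compound is needed for the effect, a lower number that less compound is needed), compound 1 gives 1 ug/mL. That is the only number shown for this assay; the second value is a limit rather than a measurement. Compound 2, `Nc1cccc(C2=NNC(=O)CC2)c1`, is the compound with that limit. In this assay compound 2 gives > 46.4 ug/mL, a limit of the assay and not a number. Of the two values shown, one sits at the limit of > 46.4 ug/mL in this assay, at which 1 of the 2 values shown sits.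

Compound 3, `C[N+]1(CC(=O)Nc2ccc(C3=NNC(=O)CC3)cc2)CCCC1`, is not yet measured in this assay. It differs from compound 1 by a group of 6 heavy atoms (5 carbon, 1 nitrogen; one five-membered non-aromatic ring with 1 hetero atom) in place of a hydrogen atom, on a saturated chain carbon bound to a carbonyl carbon.

Going by the values given here, compounds 1 and 2 differ in more than one place, so no step between measured compounds is available to set the size of a single change. The account therefore rests on compound 1 alone. A loss beyond the usual scatter is expected, the step from compound 1 to compound 3 being estimated at a 5.0-fold higher number from compound 1 to compound 3 (0.70 log units; beyond the scatter). Compound 3 is accordingly expected to give about 5 ug/mL in this assay, within an estimated range from 1 ug/mL to 30 ug/mL.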

Compound 3, half-maximal effective concentration: > 46.4 ug/mL
Compound 3 ended at the assay's limit; the forecaster's own chance of this, stated with the estimate: 25%; middle value at least 9.2-fold (0.96 log units) from the limit.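

For the compounds shown here, the step from the acetamide of compound 1 is the first single change that can be read in this assay, since the two earlier compounds differed in more than one place. It is large and beyond the scatter: an at least 46-fold higher number from compound 1 to compound 3 (1.66 log units; beyond the scatter). This shows that the saturated chain carbon bound to a carbonyl carbon is not a free place in this assay, at least for a five-membered non-aromatic ring with net charge +1 set there in place of a hydrogen atom. Compound 3 stands at a limit of the assay and not at a number, so the step gives only a lower bound on the loss, and the read-out is capped for most of the set: the limit of > 46.4 ug/mL in this assay, at which 2 of the 3 values shown sit.

The compounds shown cannot separate the ring from the charge, so it remains open whether a dimethylamino group on the same carbon would bring the same loss. Nor do they say whether a single methyl group there would keep the number of compound 1, which leaves the size a group may have at this place unsettled.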